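From 4-methoxyphenyl to 2-methoxyphenyl on the carbonyl

The compounds below may be only part of what the source reports. "The series", "measured", "known", "first", "only" and "open" are said of these compounds alone.

In a functional assay on MDA-MB-231 cells (Homo sapiens), read by microscopy and transwell migration, with a stated time of 24 h (on this read-out lower numbers stand for stronger inhibition and higher numbers for weaker inhibition), compound 3 (`COc1ccc(C(=O)N(C)c2nc(-c3cc(OC)c(OC)c(OC)c3)cs2)cc1`) gives 312 nM. Within the scatter of that value lies compound 2 (`CN(C(=O)c1ccccc1)c1nc(-c2cccc(Br)c2)cs1`) at 437 nM. Compound 1 (`COc1ccc(C(=O)Nc2nc(-c3cc(OC)c(OC)c(OC)c3)cs2)cc1`) gives no number, only a limit of the assay, > 25000 nM.

Among the compounds with values here, the one measured step, an at least 80-fold lower number from compound 1 to compound 3 (1.90 log units; beyond the scatter), is large and comes with methyl in place of hydrogen on an amide-type nitrogen. Its size is reckoned against (the limit of > 25000 nM in this assay, at which 1 of the 3 values shown sits).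

Compound 4 (`COc1ccccc1C(=O)N(C)c1nc(-c2cc(OC)c(OC)c(OC)c2)cs1`) keeps that methyl and carries 2-methoxyphenyl in place of 4-methoxyphenyl on a carbonyl carbon. Within the data shown here, no measured step touches this place, and the nitrogen change is not repeated, so that large size is not carried over. From compound 3 at 312 nM, a modest move towards a higher number in this assay is expected, though the data do not fix its direction firmly. The expected size is a 1.6-fold higher number from compound 3 to compound 4 (0.20 log units; within the scatter). Compound 4 is estimated at 500 nM, with an expected range of 150 nM to 2500 nM.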

Compound 4, half-maximal inhibitory concentration: > 25000 nM
Compound 4: a limit, no number (the forecaster's own chance of this, stated with the estimate: 8%); at least 50-fold (1.69 log units) between middle value and limit.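

The group on the carbonyl carbon proves to be a sensitive place: in this assay, 2-methoxyphenyl in place of 4-methoxyphenyl gives an at least 80-fold higher number from compound 3 to compound 4 (1.90 log units; beyond the scatter), although the two groups have the same atoms. Compound 4 keeps the methyl on the amide-type nitrogen yet gives only a limit of the assay, > 25000 nM, not a number, so that methyl alone does not secure a measured value. The size of the step is reckoned against that limit: the limit of > 25000 nM in this assay, at which 2 of the 4 values shown sit.

From the compounds shown here alone, how far the true value of compound 4 lies beyond the limit stays open. Also open, going by these compounds, is how this assay would read with an amine, a carboxylic acid or a longer chain in place of the methoxy group on this phenyl ring.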